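Methylated pyrazole in place of the free pyrazole

The source may hold more compounds than are shown below. What is called first, only, known or untested is meant among the compounds shown, and "the series" means these compounds.

Measured compounds:
Compound 1, `Cc1cc(C)c(NC(=O)N(Cc2cccc(-c3nn[nH]n3)c2)C2CCCCCC2)c(C)c1`: in an assay on microsomes from intestine for inhibition of acyl-CoA:cholesterol acyltransferase (Oryctolagus cuniculus) (a higher number here means a weaker inhibitor, a lower number a stronger inhibitor), compound 1 sits at the assay limit of > 1000 nM, which is a limit and not a number.
Compound 2, `Cc1cc(C)c(NC(=O)N(Cc2cccc(-c3cc[nH]n3)c2)C2CCCCCC2)c(C)c1`: in this assay compound 2 gives 65 nM.
Compound 3, `Cc1cc(C)c(NC(=O)N(Cc2cccc(-c3cn[nH]c3)c2)C2CCCCCC2)c(C)c1`: in this assay compound 3 gives 38 nM.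

Compound 3 holds the lowest of the two numbers, yet the step of a 1.7-fold lower number from compound 2 to compound 3 (0.23 log units; within the scatter) lies within the scatter, so compound 2 and compound 3 cannot be told apart. Compound 1 is known only through a limit (the limit of > 1000 nM in this assay, at which 1 of the 3 values shown sits). Both moves away from the tetrazole, an at least 15-fold lower number from compound 1 to compound 2 (1.18 log units; beyond the scatter) and an at least 26-fold lower number from compound 1 to compound 3 (1.42 log units; beyond the scatter), were large.

Compound 4, `Cc1cc(C)c(NC(=O)N(Cc2cccc(-c3ccnn3C)c2)C2CCCCCC2)c(C)c1`, awaits measurement and carries 1-methyl-1H-pyrazol-5-yl in place of 1H-pyrazol-4-yl on an aromatic carbon. Within the data shown here, no measured step exchanges a free pyrazole for a methylated one; the two measured pyrazoles agree within the scatter, which suggests the attachment point itself matters little. A small step, a 2.1-fold higher number from compound 3 to compound 4 (0.32 log units; beyond the scatter), toward a weaker inhibitor is expected. Compound 4 is expected to give 80 nM in this assay, within 25 nM to 300 nM.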

Compound 4, half-maximal inhibitory concentration: 35 nM
Compound 4: the middle estimate sits 2.3-fold (0.36 log units) above what was measured; the range from low to high includes it.
By their numbers in this assay, from the lowest: compounds 4, 3 and 2 (each within the scatter of the next). At a limit, above all of these: compound 1.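

The 1-methyl-1H-pyrazol-5-yl group has 0 hydrogen-bond donors where 1H-pyrazol-4-yl has 1, yet with a 1.1-fold lower number from compound 3 to compound 4 (0.04 log units; within the scatter) and a 1.9-fold lower number from compound 2 to compound 4 (0.27 log units; within the scatter) compound 4 cannot be told apart from either free pyrazole in this assay, so a donor on this ring is not required at this position. The large step away from the tetrazole also holds without that donor, with an at least 28-fold lower number from compound 1 to compound 4 (1.45 log units; beyond the scatter). Compound 1 remains a limit and not a number: the limit of > 1000 nM in this assay, at which 1 of the 4 values shown sits.

Compound 4 changes the methyl and the attachment point together, so their separate contributions stay unresolved. As far as these compounds go, whether an ethyl, a longer chain or an amine could replace that methyl also remains open.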